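Glycosyl triazole conjugates tested against breast cancer cells

The compounds below may be only part of what the source reports. "The series", "measured", "known", "first", "only" and "open" are said of these compounds alone.

Compound 1 `COc1ccc2c(c1)c(C=O)cn2Cc1cn([C@@H]2O[C@H](COC(C)=O)[C@@H](OC(C)=O)[C@H](OC(C)=O)[C@H]2OC(C)=O)nn1`, compound 2 `CC(=O)OC[C@H]1O[C@@H](n2cc(Cn3cc(C(C)=O)c4ccccc43)nn2)[C@H](OC(C)=O)[C@@H](OC(C)=O)[C@@H]1OC(C)=O` and compound 3 `CC(=O)OC[C@H]1O[C@@H](n2cc(Cn3cc([N+](=O)[O-])c4ccccc43)nn2)[C@H](OC(C)=O)[C@@H](OC(C)=O)[C@@H]1OC(C)=O` share a peracetylated sugar joined through a triazole to the shared core, and differ only in the substituent on that core. In a functional assay on MCF7 cells (Homo sapiens) for cytotoxicity, read by sulforhodamine B assay, with a stated time of 48 h (a higher number here means a weaker inhibitor, a lower number a stronger inhibitor), compound 1 reaches only a limit, > 200000 nM. In this assay compound 2 also gives a limit, > 200000 nM. Compound 3 likewise gives a limit, > 200000 nM. Within the data shown here, the single measured step, a step that the two limits leave unreadable from compound 2 to compound 3, is therefore unreadable, and because of the limit of > 200000 nM in this assay, at which 3 of the 3 values shown sit, no step size anywhere in this set is known.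

Compound 4 `CC(=O)OC[C@H]1O[C@@H](n2cc(Cn3cc(/C=C/C(=O)c4cccnc4)c4ccccc43)nn2)[C@H](OC(C)=O)[C@@H](OC(C)=O)[C@@H]1OC(C)=O` differs from compound 3 by 2-((pyridin-3-yl)carbonyl)ethenyl in place of nitro on an aromatic carbon. Among the measured compounds shown here, no measured step bears on this change: the step from compound 2 to compound 3 swaps one small group for another and ends at the limit at both ends, so it gives neither a size nor a direction. The exchange here is far larger than that one, and a move beyond the scatter is possible, but nothing measured says which way. For compound 4 the estimate is 50000 nM, with a range from 8000 nM to 200000 nM. This estimate means an expected step of an at least 4.0-fold lower number from compound 3 to compound 4 (0.60 log units; beyond the scatter), while a repeat of a bare limit remains quite likely.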

Compound 4, half-maximal inhibitory concentration: 22300 nM
Estimate against measurement, compound 4: 2.2-fold (0.35 log units) above; the measured number falls inside the stated range.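

Putting 2-((pyridin-3-yl)carbonyl)ethenyl in place of nitro on this aromatic carbon, two ring bonds from the ring nitrogen, gives the only value in this assay shown here that is a number and not a limit, with an at least 8.9-fold lower number from compound 3 to compound 4 (0.95 log units; beyond the scatter). The same group in place of acetyl at this position gives an at least 8.9-fold lower number from compound 2 to compound 4 (0.95 log units; beyond the scatter), so this substituent separates compound 4 from both smaller-substituent compounds, while nitro and acetyl give no such separation. Both steps are bounds and not exact sizes, and the step between the two limit compounds cannot be read, because of the assay limit: the limit of > 200000 nM in this assay, at which 3 of the 4 values shown sit.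

The compounds shown leave open which part of the entering group goes with the lower number: the pyridine ring, the carbonyl or the double bond, and a phenyl ring in place of the pyridine or a saturated chain in place of the ethenyl would separate these parts. Also open, from the compounds shown here alone, is whether an amine or a carboxylic acid on the pyridine ring would move the number further in either direction.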